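Methyl added on the amine nitrogen: compound 3 to compound 4

The compounds below may be only part of what the source reports. "The series", "measured", "known", "first", "only" and "open" are said of these compounds alone.

Measured so far in an ADME assay on microsomes from liver (Homo sapiens) for metabolic stability, with a stated time of 60 min, tested at 1 uM; a higher number here means that more of the compound is left, a lower number that less of the compound is left:
compound 1, `COc1cc(-c2cnn3cc(OC)c(C(C)C)nc23)ccn1`, 40%
compound 2, `Cn1cc(-c2nc3c(-c4ccnc(OC5CC5)c4)cnn3cc2OCCCC(C)(C)O)cn1`, 54%
compound 3, `CNc1nc2c(-c3ccnc(OC)c3)cnn2cc1OC`, 63%

Compound 3 gives the highest of the three numbers in this assay. Its nearest neighbour is compound 2, whose value lies within the scatter of that of compound 3, so no order between these two can be claimed. For the measured compounds named here, compound 1 lies furthest away, and the one single-place step among the measured compounds, a number 23 percentage points higher from compound 1 to compound 3 (beyond the scatter), sets compound 3 apart from compound 1 beyond the scatter.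

Compound 4, `COc1cc(-c2cnn3cc(OC)c(N(C)C)nc23)ccn1`, differs from compound 3 by methyl in place of hydrogen on a nitrogen on an aromatic ring.

Going by the values given here, no measured step shares this change; the step from compound 1 to compound 3 concerns methylamino in place of isopropyl and says nothing about a further methyl on that nitrogen. With nothing to go on beyond the value of compound 3 itself, the expectation for compound 4 is a step of a number 5 percentage points lower from compound 3 to compound 4 (within the scatter), that is, no step beyond the scatter, with the range kept wide. Compound 4 is therefore estimated at 58%, between 40% and 75%.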

Compound 4, percent of the compound remaining: 16%
For compound 4 the middle estimate is 42 percentage points above the measured one; measured number below the stated range.
By their numbers in this assay, from the lowest: compound 4; then compound 1; then compounds 2 and 3 (each within the scatter of the next).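

In this assay, for the compounds shown here, the methyl on the amine nitrogen is anything but a small change: the read-out gives a number 47 percentage points lower from compound 3 to compound 4 (beyond the scatter), the largest step so far. Dimethylamino in place of isopropyl on the aromatic carbon gives a number 24 percentage points lower from compound 1 to compound 4 (beyond the scatter), the opposite direction to a number 23 percentage points higher from compound 1 to compound 3 (beyond the scatter), so among these three compounds the gain over isopropyl belongs to methylamino and does not extend to dimethylamino. Nothing at hand bears on why a single methyl has this effect.

As far as these compounds go, whether the unsubstituted amine, ethylamino or a ring amine such as azetidine would stand with compound 3 or with compound 4 stays open. Also open, from the compounds shown here alone, is whether methylamino to dimethylamino would give a step of similar size with other groups on the shared core.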